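Methyl for phenyl on the ring nitrogen: compound 4

The compounds below may be only part of what the source reports. "The series", "measured", "known", "first", "only" and "open" are said of these compounds alone.

Three compounds of the shared core have been run in a functional assay on C6 cells (Rattus norvegicus) for cytotoxicity, read by MTT assay, with a stated time of 24 h, tested at 100 ug/mL; on this read-out lower numbers stand for a stronger effect and higher numbers for a weaker effect at the one concentration tested. Compound 1 `O=C(CSc1nnnn1-c1ccccc1)N/N=c1/scc(-c2ccc(Br)cc2)n1-c1ccccc1` gives 24.3%, compound 2 `Cc1ccc(-c2cs/c(=N/NC(=O)CSc3nnnn3-c3ccccc3)n2-c2ccccc2)cc1` gives 28.5% and compound 3 `O=C(CSc1nnnn1-c1ccccc1)N/N=c1/scc(-c2ccc(F)cc2)n1-c1ccccc1` gives 35.8%. Compound 2 stands second highest of the three numbers, within the scatter of both compound 1 and compound 3. All measured steps exchange the substituent on the aromatic carbon: a number 4.2 percentage points higher from compound 1 to compound 2 (within the scatter) and a number 7.3 percentage points higher from compound 2 to compound 3 (within the scatter), both within the scatter, and a number 11.5 percentage points higher from compound 1 to compound 3 (beyond the scatter), the only one reaching beyond it.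

Compound 4 `Cc1ccc(-c2cs/c(=N/NC(=O)CSc3nnnn3C)n2-c2ccccc2)cc1` differs from compound 2 in methyl in place of phenyl on an aromatic nitrogen. The same difference, cut one bond further out, reads 1-phenyl-1H-tetrazol-5-yl to 1-methyl-1H-tetrazol-5-yl. Among the compounds with values here, no measured step touches this position, so none bears on it directly, and the series gives no direction for the change. The step of a number 1.5 percentage points higher from compound 2 to compound 4 (within the scatter) is therefore expected to stay within the scatter, with a wide range allowed. The estimate for compound 4 in this assay is 30%, between 15% and 50%.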

Compound 4, a percentage reported as activity, at one concentration (the size of the read-out at that concentration, not a potency): 39.7%
Compound 4: the middle estimate sits 9.7 percentage points below what was measured; the measured number falls inside the stated range.
By their numbers in this assay, from the lowest: compounds 1, 2, 3 and 4 (each within the scatter of the next, the first and the last beyond it).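

In this assay, within the data shown here, the first change on the aromatic nitrogen of the five-membered aromatic ring with 4 nitrogen gives a number 11.2 percentage points higher from compound 2 to compound 4 (beyond the scatter). Among these compounds, this position, untouched by the earlier steps, therefore does register in the read-out: going from 1-phenyl-1H-tetrazol-5-yl to 1-methyl-1H-tetrazol-5-yl modestly weakens the effect at the one concentration tested, though this rests on a single pair. Nothing measured here accounts for this step.

On these data alone, whether the same exchange has a similar effect with bromo as in compound 1 or fluoro as in compound 3 on the aromatic carbon remains open. Also open, as far as these compounds go, is whether a benzyl group or a longer alkyl chain on this nitrogen would stay close to compound 2 or to compound 4.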